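Swapping a nitrile for hydroxycarbamoyl on a shared core

The compounds below may be only part of what the source reports. "The series", "measured", "known", "first", "only" and "open" are said of these compounds alone.

Among the compounds with values here, compound 2 `CCOc1ccc(Br)cc1-c1cc(Nc2ccc(C#N)cc2)nc(N)n1` holds the lower of the two numbers so far. In a functional assay on K562 cells (Homo sapiens) for inhibition (on this read-out lower numbers stand for stronger inhibition and higher numbers for weaker inhibition), compound 2 gives 70 nM as its reading, while compound 1 `CCOc1ccc(Br)cc1-c1cc(Nc2ccc(B(O)O)cc2)nc(N)n1` gives 200 nM as its reading. The next molecule, compound 3 `CCOc1ccc(Br)cc1-c1cc(Nc2ccc(C(=O)NO)cc2)nc(N)n1`, keeps the core and changes one group: hydroxycarbamoyl in place of cyano on an aromatic carbon is the whole difference, hydroxycarbamoyl in place of cyano on an aromatic carbon. Within the data shown here, only one measured step bears on this spot. Swapping the group at this same place gave a 2.9-fold lower number from compound 1 to compound 2 (0.46 log units; beyond the scatter) and that step is modest, though beyond the scatter. It shows that the read-out can move with this group, but one pair cannot predict how a new group will behave, so the direction stays uncertain. Going by that single step, a 2.9-fold lower number from compound 1 to compound 2 (0.46 log units; beyond the scatter), a change of similar modest size is expected, leaning toward weaker inhibition. The expected move is a 1.9-fold higher number from compound 2 to compound 3 (0.27 log units; within the scatter) in this estimate. Compound 3 is estimated at 130 nM with an expected range from 25 nM to 600 nM in repeat measurements.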

Compound 3, half-maximal inhibitory concentration: 700 nM
The estimate for compound 3 lay 5.4-fold (0.73 log units) below the measured number; measured number above the stated range.
By their numbers in this assay, from the lowest: compound 2; then compound 1; then compound 3.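

Within the data shown here, measured by this assay, the group on this aromatic carbon matters more than the first pair could show: hydroxycarbamoyl in place of cyano gives a 10-fold higher number from compound 2 to compound 3 (1.00 log units; beyond the scatter) and is the largest step so far. Hydroxycarbamoyl also does worse than the boron-bearing group, with a 3.5-fold higher number from compound 1 to compound 3 (0.54 log units; beyond the scatter) as the step, so across these three compounds the number rises each time the group on this carbon gains heavy atoms, and none of the three goes against that order. Nothing measured here says what lies behind this order.

Three compounds cannot show whether the rise follows the size of the group, because the groups also differ in their atoms and in their hydrogen-bond donors and acceptors. A carboxylic acid or a plain amide at this place would help separate these features from hydroxycarbamoyl itself, while an amine or a single fluorine would show whether a group smaller than cyano keeps the number as low as compound 2 does.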